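Ethoxy in Place of Isopropyl on Compound 3

The source may hold more compounds than are shown below. What is called first, only, known or untested is meant among the compounds shown, and "the series" means these compounds.

Of the compounds shown here, three have so far been measured in a functional assay on MCF7 cells (Homo sapiens) for cytotoxicity; on this read-out higher numbers stand for an effect only at larger amounts of compound and lower numbers for an effect already at smaller amounts. Compound 1 `COc1cc(/C=C\c2ccc(C(C)C)cc2)cc(OC)c1OC` gives 1.4 uM, and compound 2 `COC(=O)/C(=C/c1cccc(OC)c1)c1cc(OC)c(OC)c(OC)c1` gives 1.3 uM; these two numbers lie within the scatter of each other. Compound 3 `COc1cc(/C=C/c2ccc(C(C)C)cc2)cc(OC)c1OC` gives 18.4 uM, the highest of the three numbers. Going by the values given here, the only step between compounds that differ in a single place runs from compound 1 to compound 3: a 13-fold higher number from compound 1 to compound 3 (1.12 log units; beyond the scatter), a shift that rests on (the fact that compounds 1 and 3 differ only in the configuration as drawn). Among the compounds with values here, compound 2 and compound 3 differ in several places at once and share no measured step; their two numbers simply stand far apart.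

The next compound, compound 4 `CCOc1ccc(/C=C/c2cc(OC)c(OC)c(OC)c2)cc1`, is reached from compound 3 by ethoxy in place of isopropyl on an aromatic carbon. The double bond keeps the configuration drawn in compound 3. Within the data shown here, none of the measured steps concerns an exchange of this kind, so no measured step bears on it directly, and the expectation can rest only on the scale of the numbers seen so far. An exchange at a single ring position is expected to move the number less than the configuration step did, so the estimated step is a 1.8-fold lower number from compound 3 to compound 4 (0.26 log units; within the scatter), a modest shift or none beyond the scatter. Compound 4 is therefore estimated at 10 uM, with a range from 2.5 uM to 40 uM.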

Compound 4, concentration for half-maximal effect: 7.5 uM
Compound 4: middle estimate off by 1.3-fold (0.12 log units), on the high side; the measured number falls inside the stated range.
By their numbers in this assay, from the lowest: compounds 2 and 1 (each within the scatter of the next); then compound 4; then compound 3.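

Going by these compounds alone, the exchange gives the first measured evidence that the ring carbon para to a large group affects the read-out while the double bond stays as drawn in compound 3: in this assay there is a 2.5-fold lower number from compound 3 to compound 4 (0.39 log units; beyond the scatter). Until now, the only single-place step concerned the configuration of the double bond, a 13-fold higher number from compound 1 to compound 3 (1.12 log units; beyond the scatter), so nothing had shown how this position responds to a change of group. Here, isopropyl and ethoxy have the same count of heavy atoms, but ethoxy brings an oxygen in place of a carbon and a hydrogen-bond acceptor, and this exchange shifts the number modestly but beyond the scatter, though nothing at hand explains the shift.

It remains open whether ethoxy in place of isopropyl would move the number in the same direction and to a similar extent on compound 1, where the double bond is drawn Z. The compounds shown also leave open how the number would respond at this position to a longer chain such as butoxy, to an amine or to a carboxylic acid.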